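Amide in place of acid on a naphthyl and indazolyl pair

This account rests on a few compounds, and the source may have more. Where it says the series, first, only, none or still open, it means among the compounds named here.

Compound 1 `CNC(=O)/C=C/c1ccncc1-c1ccc2ccccc2c1` gives 8680 nM. Compound 2 `O=C(O)/C=C/c1ccncc1-c1ccc2ccccc2c1` gives only a limit, > 10000 nM. Compound 3 `Cn1ncc2cc(-c3cnccc3/C=C/C(=O)O)ccc21` likewise gives only a limit, > 10000 nM.

All three were tested in a functional assay on MDA-MB-231 cells (Homo sapiens) for inhibition, read by sulforhodamine B assay, with a stated time of 72 h; on this read-out higher numbers stand for weaker inhibition of growth and lower numbers for stronger inhibition of growth. For compound 2 the result is a limit and not a number. Compound 1, which differs by methylamino in place of hydroxy on a carbonyl carbon, gives a number, and the step of an at least 1.1-fold lower number from compound 2 to compound 1 (0.06 log units; that floor lies within the scatter) is all that can be read from the pair, because two of the three results sit at the limit of > 10000 nM in this assay, at which 2 of the 3 values shown sit.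

Compound 3 carries a different core; the difference between the two cores is not broken down here. In this assay compound 3 gives a limit rather than a number. Compound 4 `CNC(=O)/C=C/c1ccncc1-c1ccc2c(cnn2C)c1` is made from compound 3 by methylamino in place of hydroxy on a carbonyl carbon, the same change as from compound 2 to compound 1. Since the earlier step rests on a limit and stays within the usual scatter, compound 4 is expected to land near the limit as well, with the step of an at least 1.1-fold lower number from compound 3 to compound 4 (0.04 log units; that floor lies within the scatter) as the estimate. The expected value for compound 4 is 9000 nM, between 3000 nM and 30000 nM.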

Compound 4, concentration for 50% growth inhibition: > 10000 nM
Compound 4: only a limit was reported; the forecaster's own chance of this, stated with the estimate: 55%; middle value at least 1.1-fold (0.04 log units) away from the limit.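

Compound 4, like compound 3, gives only a limit in this assay, so no step can be read between the two compounds: the limit of > 10000 nM in this assay, at which 3 of the 4 values shown sit.

Still open, from the compounds shown here alone, is how strongly compound 3 and compound 4 inhibit growth, and whether methylamino in place of hydroxy on a carbonyl carbon changes that inhibition on the core of compound 3.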